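Cyano for Methyl on the Benzamide Ring

This account rests on a few compounds, and the source may have more. Where it says the series, first, only, none or still open, it means among the compounds named here.

Compound 1 `O=C(CNC(=O)c1ccc(F)cc1)N/N=C/c1ccccc1OCc1ccccc1Cl`: 24900 nM
Compound 2 `Cc1ccc(C(=O)NCC(=O)N/N=C/c2ccccc2OCc2ccccc2Cl)cc1`: 13400 nM
Compound 3 `Cc1ccc(C(=O)NCC(=O)N/N=C/c2ccccc2OCc2ccc(C#N)cc2)cc1`: > 50000 nM

The value given for compound 3 is a limit of the measurement, not a number.

In a functional assay on HepG2 cells (Homo sapiens) for inhibition, read by MTT assay, with a stated time of 24 h (a higher number here means a weaker inhibitor, a lower number a stronger inhibitor), compound 2 stands at the lowest of the two numbers shown. Its nearest neighbour is compound 1, and the step of a 1.9-fold lower number from compound 1 to compound 2 (0.27 log units; within the scatter) lies within the scatter, so the two cannot be ranked against each other. The third value is the limit (the limit of > 50000 nM in this assay, at which 1 of the 3 values shown sits).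

Compound 4 `N#Cc1ccc(C(=O)NCC(=O)N/N=C/c2ccccc2OCc2ccccc2Cl)cc1` has not yet been measured. It differs from compound 2 by cyano in place of methyl on an aromatic carbon. Going by the values given here, two measured steps bear on this. The step of an at least 3.7-fold higher number from compound 2 to compound 3 (0.57 log units; beyond the scatter) also brought a cyano group into the molecule, though on the other aromatic ring, and pushed the value to the limit. The step of a 1.9-fold lower number from compound 1 to compound 2 (0.27 log units; within the scatter), a swap on the same ring that compound 4 alters, stayed within the scatter. Weighing the two, the cyano step is expected to weaken inhibition, by about a 2.2-fold higher number from compound 2 to compound 4 (0.35 log units; beyond the scatter). Compound 4 is therefore estimated at 30000 nM, within a range of 12000 nM to 80000 nM, with a real chance that only a limit is reported.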

Compound 4, half-maximal inhibitory concentration: > 50000 nM
Compound 4: no number, only a limit; the forecaster's own chance of this, stated with the estimate: 35%; at least 1.6-fold (0.22 log units) between middle value and limit.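

The position para to a large group proves sensitive to what sits on it. Fluoro and methyl there could not be told apart, whereas cyano in place of methyl gives an at least 3.7-fold higher number from compound 2 to compound 4 (0.57 log units; beyond the scatter). Cyano in place of fluoro gives an at least 2.0-fold higher number from compound 1 to compound 4 (0.30 log units; that floor lies within the scatter), and that floor alone does not separate the two compounds. Compound 3 and compound 4, with a cyano group on different aromatic rings, both end at a limit of the measurement rather than a number: the limit of > 50000 nM in this assay, at which 2 of the 4 values shown sit.

On these data alone, with both values at that limit, the full size of the cyano step stays unknown, and compound 3 and compound 4 cannot be ranked against each other. Also open, as far as these compounds go, is whether an amine or a carboxylic acid at this same position would keep inhibition near that of compound 2.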